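The source may report more compounds than this note shows. Statements on the series, on what has been measured and on what is new or still open speak of the compounds shown alone.

Measured compounds:
Compound 1 `Cc1c(C(=O)CSCCO)[n+]([O-])c2ccccc2[n+]1[O-]` — in an ADME assay on Vero cells (Chlorocebus sabaeus) for cytotoxicity, read by MTT assay, with a stated time of 72 h (on this read-out higher numbers stand for lower toxicity in this test and lower numbers for higher toxicity in this test), compound 1 gives "not determined" (no result reported)
Compound 2 `Cc1c(C(=O)CSc2ccccc2)[n+]([O-])c2ccccc2[n+]1[O-]` — in this assay compound 2 gives 50 ug/mL
Compound 3 `Cc1c(C(=O)CSc2nc[nH]n2)[n+]([O-])c2ccccc2[n+]1[O-]` — in this assay compound 3 gives 50 ug/mL

All three compounds share the same core and differ only in the group attached to the sulfur. On the numbers shown, compound 1 stands nowhere: no result was reported for it in this assay, so there is no starting value for the step to compound 4.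

Compound 4 `Cc1c(C(=O)CSCCNC(=O)c2ccncc2)[n+]([O-])c2ccccc2[n+]1[O-]` is not yet measured. It arises from compound 1 by the change (((pyridin-4-yl)carbonyl)amino in place of hydroxy on a saturated chain carbon, two bonds along the chain from a sulfur).

Going by the values given here, only one measured step is available for comparison: no change at the digits printed from compound 2 to compound 3 (within the scatter). That step exchanges one ring for another directly on the sulfur, whereas the change from compound 1 to compound 4 acts further along the chain, so it bears on the question only loosely. What it does show is that two quite different groups on the sulfur left the read-out in this assay unchanged within the scatter, and both compound 2 and compound 3 sit at the same value. With no value for compound 1, the expectation for compound 4 can rest only on that shared level, with no direction of step beyond the scatter to point to.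

Compound 4 is therefore expected to give about 50 ug/mL in this assay, within a range of 15 ug/mL to 150 ug/mL.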

Compound 4, half-maximal cytotoxic concentration: 50 ug/mL
Compound 4: middle estimate and measured number agree at the digits printed; the measured number falls inside the stated range.
By their numbers in this assay, from the lowest: compounds 2, 3 and 4 (each within the scatter of the next).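

In this assay, going by these compounds alone, compound 1 gives "not determined" (no result reported) and so no step to compound 4 can be read. The compounds shown leave open what ((pyridin-4-yl)carbonyl)amino in place of hydroxy does to this read-out, and whether any other group on the sulfur would shift it. Nothing shown offers an explanation for these results.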